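This account rests on a few compounds, and the source may have more. Where it says the series, first, only, none or still open, it means among the compounds named here.

Measured in an ADME assay on microsomes from liver (Mus musculus) for metabolic stability, read by LC-MS, with a stated time of 10 min, tested at 0.5 uM; on this read-out lower numbers stand for a less stable compound and higher numbers for a more stable compound:
- compound 1 `c1ccc2c(c1)CN[C@@H](CN(CCC1CCNCC1)[C@H]1CCCc3cccnc31)C2`: 32%
- compound 2 `c1cnc2c(c1)CCC[C@@H]2N(CCCN1CCNCC1)Cc1cc2ccccc2cn1`: 74%

Compound 1 has the lower of the two numbers, and compound 2 lies higher by a margin beyond the scatter. These two do not differ in just one place, so the measured data contain no direct guide to a single change.

Compound 3 `c1ccc2c(c1)CN[C@@H](CN(CC[C@H]1CCCNC1)[C@H]1CCCc3cccnc31)C2` is not yet measured. It has the same atoms as compound 1, joined differently, with piperidin-3-yl in place of piperidin-4-yl on a saturated chain carbon, two bonds along the chain from an amine nitrogen. The expectation therefore rests on compound 1 at 32%. The estimated step is a number 3 percentage points higher from compound 1 to compound 3 (within the scatter), expected to stay within the scatter in this assay. For compound 3 the estimated value is 35%, with an expected range of 18% to 55%.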

Compound 3, percent of the compound remaining: 56%
Compound 3: middle estimate off by 21 percentage points, on the low side; the whole stated range lies below it.
By their numbers in this assay, from the lowest: compound 1; then compound 3; then compound 2.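

In this assay, piperidin-3-yl in place of piperidin-4-yl on a saturated chain carbon, two bonds along the chain from an amine nitrogen, gives a number 24 percentage points higher from compound 1 to compound 3 (beyond the scatter) for this one pair. This place therefore responds to how the same atoms are joined: the two groups match in heavy atoms, hydrogen-bond donors, hydrogen-bond acceptors and net charge, and the entering group differs in carrying one defined stereocentre. Nothing at hand accounts for the step.

Open questions are whether the opposite stereoisomer of the piperidin-3-yl group reads like compound 3, and whether the step carries over to another core. Also open, on these data alone, is how piperidin-2-yl, a morpholine ring or a longer chain would read at this place.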